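A Methyl Group Enters the Benzamide Ring of Compound 2

A few compounds are considered here, and "the series" means these few. Any claim that something is new, unique, unknown or untested is made for them only; others in the source may bear on it.

Compound 1 `O=C(NC(=S)NNc1ncnc2ccccc12)c1ccc(Cl)cc1` gives 1860 nM in a functional assay on MGC-803 cells (Homo sapiens) for cytotoxicity, read by MTT assay, with a stated time of 72 h; a lower number here means a stronger inhibitor, a higher number a weaker inhibitor.
Compound 2 `O=C(NC(=S)NNc1ncnc2ccccc12)c1ccccc1` gives 6990 nM in this assay.

Compound 2 stands highest of the two numbers; its nearest neighbour is compound 1, and the step of a 3.8-fold higher number from compound 1 to compound 2 (0.57 log units; beyond the scatter) came with hydrogen in place of chloro on an aromatic carbon. Compound 3 `Cc1ccccc1C(=O)NC(=S)NNc1ncnc2ccccc12` differs from compound 2 in one place: methyl in place of hydrogen on an aromatic carbon. Among the compounds with values here, only one measured step exists, and it concerns a different substituent at a different place on the same ring, so it bears on the new change only loosely; it does show that a single small group on this ring can shift the number in this assay by a modest amount. For compound 3 a step about the size of the scatter is therefore expected, with a slight lean toward a lower number, a 1.4-fold lower number from compound 2 to compound 3 (0.15 log units; within the scatter). Compound 3 is estimated at 5000 nM, in the range 2000 nM to 15000 nM.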

Compound 3, half-maximal inhibitory concentration: 4240 nM
For compound 3 the middle estimate is 1.2-fold (0.07 log units) above the measured one; low and high end bracket the measured number.
By their numbers in this assay, from the lowest: compound 1; then compounds 3 and 2 (each within the scatter of the next).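

In this assay, within the data shown here, methyl on an aromatic carbon ortho to a large group gives a 1.6-fold lower number from compound 2 to compound 3 (0.22 log units; within the scatter), so this place on the ring takes a methyl with no step that stands clear of the scatter. The 2-methylphenyl group does not match the 4-chlorophenyl group, since the change between them gives a 2.3-fold higher number from compound 1 to compound 3 (0.36 log units; beyond the scatter) and leaves compound 1 apart from both compound 2 and compound 3. Nothing at hand bears on why either step has the size it has.

On these data alone, whether a longer chain such as ethyl, or an amine, at this same place would move the number beyond the scatter remains open. As far as these compounds go, it is also open whether chloro at this place would give a number like that of compound 1.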